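A Halogen Exchange Repeated on a Second Core

The source may report more compounds than this note shows. Statements on the series, on what has been measured and on what is new or still open speak of the compounds shown alone.

Compound 1 `Cc1ccc2nc(Cl)c(/C=C/C(=O)c3ccc(Cl)s3)cc2c1` and compound 3 `Cc1ccc2nc(Cl)c(/C=C/C(=O)c3ccc(Br)s3)cc2c1` share one core, while compound 2 `Cc1cccc2cc(/C=C/C(=O)c3ccc(Br)s3)c(Cl)nc12` has the same atoms joined differently; the difference between the two cores is not broken down here. In a functional assay on HUVEC cells (Homo sapiens), read by BrdU incorporation, with a stated time of 72 h (on this read-out higher numbers stand for weaker inhibition and lower numbers for stronger inhibition), compound 1 gives 59.4 nM, compound 3 gives 88.4 nM, and compound 2 gives 243 nM, the highest of the three numbers. Compound 3 and compound 1 differ by chloro in place of bromo on an aromatic carbon, and that step reads a 1.5-fold lower number from compound 3 to compound 1 (0.17 log units; within the scatter). Compound 4 `Cc1cccc2cc(/C=C/C(=O)c3ccc(Cl)s3)c(Cl)nc12`, not yet measured, differs from compound 2 by chloro in place of bromo on an aromatic carbon, the same change, at the same place. In this assay compound 4 is expected to show a 1.4-fold lower number from compound 2 to compound 4 (0.16 log units; within the scatter), a step of similar small size, because the earlier step of a 1.5-fold lower number from compound 3 to compound 1 (0.17 log units; within the scatter) stayed within the scatter. The estimate for compound 4 is 170 nM, with a range from 80 nM to 360 nM.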

Compound 4, half-maximal inhibitory concentration: 116 nM
The estimate for compound 4 lay 1.5-fold (0.17 log units) above the measured number, and the stated range covers the measured number.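

In this assay, among the compounds shown here, replacing 5-bromothiophen-2-yl with 5-chlorothiophen-2-yl gives a 2.1-fold lower number from compound 2 to compound 4 (0.32 log units; beyond the scatter), and the steps on the two cores do not differ beyond the scatter: the same change on two cores in this assay, a 1.5-fold lower number (0.17 log units; within the scatter) from compound 3 to compound 1 and a 2.1-fold lower number (0.32 log units; beyond the scatter) from compound 2 to compound 4, 1.4-fold (0.15 log units) apart, within the scatter of two such steps On these two pairs, then, the size of the step carries over from one core to the other, although only the step on the core of compound 2 lies beyond the scatter. Two pairs do not show that the step would hold on any further core, and they do not explain its size.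

The compounds shown leave open how a methyl group, a nitrile or an amine would read in place of the bromo or chloro. They also leave open whether any such group would give steps of similar size on both cores.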